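The compounds below may be only part of what the source reports. "The series", "measured", "known", "first", "only" and "open" are said of these compounds alone.

The measurements here come from an assay on liver for inhibition of sterol O-acyltransferase 1 (Rattus norvegicus), using microsomes; on this read-out higher numbers stand for weaker inhibition and lower numbers for stronger inhibition. Three compounds carry numbers in it. Compound 1 `CCCCCCCCCCCCOS(=O)(=O)NC(=O)Nc1c(C(C)C)cccc1C(C)C` gives 5000 nM; 6800 nM (2 entries), two repeat entries that sit close together (the several entries of compound 1 in this assay, 5000 nM; 6800 nM (2 entries)). Compound 2 `CCC(C)N(C(=O)NS(=O)(=O)Oc1c(C(C)C)cccc1C(C)C)C(C)CC` gives 12000 nM. Compound 3 `CCCCCCCCCCCCOC(=O)NS(=O)(=O)Nc1c(C(C)C)cccc1C(C)C` gives 33000 nM. Of the two compounds with a single number, compound 2 has the lower one; its nearest neighbour is compound 3, whose number is higher by a gap beyond the usual scatter, while compound 1 contributes two entries rather than one.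

Compound 4 `Cc1cccc(C)c1OC(=O)NS(=O)(=O)Oc1c(C(C)C)cccc1C(C)C` has not yet been measured. It differs from compound 2 in one place: 2,6-dimethylphenoxy in place of bis(sec-butyl)amino on a carbonyl carbon. Going by the values given here, no measured pair isolates this exact change, so no step for it is known. A modest move toward weaker inhibition is expected in this assay. The other carbamate shown, compound 3, gives 33000 nM. The expected step from compound 2 to compound 4 is a 1.5-fold higher number from compound 2 to compound 4 (0.18 log units; within the scatter). Compound 4 is therefore estimated at 18000 nM, within a range from 5000 nM to 65000 nM.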

Compound 4, half-maximal inhibitory concentration: > 50000 nM
Compound 4 ended at the assay's limit; the forecaster's own chance of this, stated with the estimate: 20%; at least 2.7-fold (0.44 log units) between middle value and limit.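

Going by these compounds alone, on the carbonyl carbon, 2,6-dimethylphenoxy in place of bis(sec-butyl)amino gives an at least 4.1-fold higher number from compound 2 to compound 4 (0.61 log units; beyond the scatter) in this assay, the first step here between compounds that differ in one place. Both groups hold 9 heavy atoms, so matching that count did not keep the inhibition when an aromatic ring and an oxygen replaced a ring-free group with a nitrogen. Compound 4 stands at a limit of the assay rather than at a number, so the step gives only a minimum size: the limit of > 50000 nM in this assay, at which 1 of the 4 values shown sits.

The compounds shown leave open whether the ring or the oxygen accounts for this step, and 2,6-dimethylanilino, which holds the same ring on a nitrogen, would separate the two. Also open, as far as these compounds go, is how a smaller amine such as dimethylamino would read on the same carbonyl carbon.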